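Swapping the Pendant Phenyl Substituent in a Cytotoxicity Series

A few compounds are considered here, and "the series" means these few. Any claim that something is new, unique, unknown or untested is made for them only; others in the source may bear on it.

Compound 1: `COc1ccccc1Oc1c(N)nc(-c2cccc(C)c2)nc1Cl` gives 65300 nM.
Compound 2: `COc1ccccc1Oc1c(N)nc(-c2ccc(C)cc2)nc1Cl` gives only a limit, > 80000 nM.
Compound 3: `COc1ccccc1Oc1c(N)nc(-c2ccccc2F)nc1Cl` gives only a limit, > 80000 nM.

Among the measured compounds shown here, in a functional assay on A-375 cells (Homo sapiens) for cytotoxicity, read by CCK-8 assay, with a stated time of 24 h (on this read-out higher numbers stand for weaker inhibition and lower numbers for stronger inhibition), compound 1 is the only member with a number of its own. For compound 3 the read-out is a limit, > 80000 nM, and not a number; it shares this with the limit of > 80000 nM in this assay, at which 2 of the 3 values shown sit. Compound 3 therefore stands at the upper edge of what the assay reports, and the steps of an at least 1.2-fold higher number from compound 1 to compound 3 (0.08 log units; that floor lies within the scatter) and a step that the two limits leave unreadable from compound 2 to compound 3 say little about its true place.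

Compound 4 is `COc1ccccc1Oc1c(N)nc(-c2cccc(I)c2)nc1Cl`. The change is 3-iodophenyl in place of 2-fluorophenyl on an aromatic carbon. For the measured compounds named here, the steps that bear on it are an at least 1.2-fold higher number from compound 1 to compound 2 (0.08 log units; that floor lies within the scatter) and an at least 1.2-fold higher number from compound 1 to compound 3 (0.08 log units; that floor lies within the scatter): both replace a 3-methylphenyl and both end at a limit. Compound 4 carries a 3-iodophenyl, the same name position as the methyl of compound 1, so a number near that of compound 1 is expected rather than a clear move in either direction; the expected step of an at least 1.1-fold lower number from compound 3 to compound 4 (0.05 log units; that floor lies within the scatter) is none beyond the scatter. The estimate for compound 4 is 70000 nM, with a range from 30000 nM to 90000 nM.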

Compound 4, half-maximal inhibitory concentration: 2200 nM
Compound 4: middle estimate off by 32-fold (1.50 log units), on the high side; measured number below the stated range.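

In this assay, exchanging methyl for iodo on the 3-substituted phenyl gives a 30-fold lower number from compound 1 to compound 4 (1.47 log units; beyond the scatter). Among the compounds shown here, this is the first change here to move a value beyond the scatter, and it shows that the group carried on this phenyl can matter far more than the earlier compounds revealed. The comparisons with the other two phenyl groups give an at least 36-fold lower number from compound 3 to compound 4 (1.56 log units; beyond the scatter) and an at least 36-fold lower number from compound 2 to compound 4 (1.56 log units; beyond the scatter), and both sizes are only floors, as their starting compounds report a limit and not a number: the limit of > 80000 nM in this assay, at which 2 of the 4 values shown sit.

The compounds shown cannot tell whether this gain is special to iodo or would also appear with a 3-bromophenyl or a 3-methoxyphenyl. They also leave open whether a 4-iodophenyl or a 2-iodophenyl would keep it.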